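Methyl for fluoro on the shared core: one small swap

A few compounds are considered here, and "the series" means these few. Any claim that something is new, unique, unknown or untested is made for them only; others in the source may bear on it.

For the measured compounds named here, compound 2 `CS(=O)(=O)c1ccc(F)cc1NCC1=NCCN1` gives 96% in a functional assay for agonist activity at Alpha-1A adrenergic receptor (Homo sapiens) (on this read-out lower numbers stand for smaller maximal responses and higher numbers for larger maximal responses), the lower of the two numbers measured so far. Compound 1 `COc1ccc(S(C)(=O)=O)c(NCC2=NCCN2)c1` gives 102% in this assay. Going by the values given here, the only measured step, a number 6 percentage points lower from compound 1 to compound 2 (within the scatter), is small. Compound 3 `Cc1ccc(S(C)(=O)=O)c(NCC2=NCCN2)c1` carries a change of the same kind: methyl in place of fluoro on an aromatic carbon. Among the compounds with values here, since the single comparable swap moved the number by so little, no step beyond the scatter is expected, and the expected step from compound 2 to compound 3 in this assay is a number 2 percentage points higher from compound 2 to compound 3 (within the scatter). Compound 3 is therefore estimated at 98% in this assay, within a range from 85% to 110%.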

Compound 3, largest response reached (reported as maximum), in percent of the reference or control that the assay uses: 98%
For compound 3 middle estimate and measured number coincide at the digits printed; the range from low to high includes it.
By their numbers in this assay, from the lowest: compounds 2, 3 and 1 (each within the scatter of the next).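

Methyl now joins fluoro and methoxy on this aromatic carbon, para to a methylsulfonyl group, and in this assay it stays close to both (a number 2 percentage points higher from compound 2 to compound 3 (within the scatter); a number 4 percentage points lower from compound 1 to compound 3 (within the scatter)). All three groups therefore lie within the scatter of one another, so this read-out does not separate them at this position. No measurement available here accounts for this. As far as these compounds go, whether an amine, a carboxylic acid or a longer chain on this carbon would also stay within the scatter remains open.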